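Aryl variation on the piperazine nitrogen of an aminothiophene series

The source may report more compounds than this note shows. Statements on the series, on what has been measured and on what is new or still open speak of the compounds shown alone.

Measured so far:
compound 1 `CC(C)N1CCN(Cc2csc(N)c2C(=O)c2ccc(Cl)cc2)CC1` gives 7.3%
compound 2 `Nc1scc(CN2CCN(c3ccc(F)cc3Cl)CC2)c1C(=O)c1ccc(Cl)cc1` gives -39%
compound 3 `Nc1scc(CN2CCN(c3cccc4ccccc34)CC2)c1C(=O)c1ccc(Cl)cc1` gives 2.9%

Three compounds share a core and differ only in the group on an amine nitrogen in a ring. In a functional assay on CHO cells with adenosine receptor A1 (Homo sapiens) as the target, read by cAMP accumulation and immunoassay, with a stated time of 6 min, tested at 1 uM (on this read-out lower numbers stand for a stronger effect and higher numbers for a weaker effect at the one concentration tested), compound 3 stands second highest of the three numbers; its nearest neighbour is compound 1, and the two lie within the scatter of each other, while compound 2 sits far below.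

Compound 4 `Nc1scc(CN2CCN(c3cccc(F)c3)CC2)c1C(=O)c1ccc(Cl)cc1` has not yet been measured. Its change from compound 3 is 3-fluorophenyl in place of naphthalen-1-yl on an amine nitrogen in a ring.

Among the measured compounds shown here, two measured steps bear on this. The step of a number 41.9 percentage points higher from compound 2 to compound 3 (beyond the scatter) shows that exchanging one aryl group for another on this nitrogen can move the read-out a long way. The step of a number 4.4 percentage points lower from compound 1 to compound 3 (within the scatter) shows that naphthalen-1-yl and isopropyl give numbers within the scatter of each other. The incoming 3-fluorophenyl is a single-ring aryl group, as is the 2-chloro-4-fluorophenyl of compound 2, so a downward step is expected, though smaller than a number 41.9 percentage points higher from compound 2 to compound 3 (beyond the scatter) reversed.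

Compound 4 is therefore estimated at -12%, within -40% to 12%, an expected step of a number 14.9 percentage points lower from compound 3 to compound 4 (beyond the scatter) in this assay.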

Compound 4, a percentage reported as activity, at one concentration (the size of the read-out at that concentration, not a potency): -86%
The estimate for compound 4 lay 74 percentage points above the measured number, and the stated range ends above it.
By their numbers in this assay, from the lowest: compound 4; then compound 2; then compounds 3 and 1 (each within the scatter of the next).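

In this assay, the group on this ring nitrogen can take the read-out much further down than compound 2 had suggested: with a number 47 percentage points lower from compound 2 to compound 4 (beyond the scatter), two single-ring aryl groups now stand far apart, so having a single aryl ring here does not fix the size of the effect. Among the four compounds, the two single-ring aryl groups give the lowest numbers, while naphthalen-1-yl and isopropyl lie within the scatter of each other, and 3-fluorophenyl separates sharply from both, with a number 88.9 percentage points lower from compound 3 to compound 4 (beyond the scatter) and a number 93.3 percentage points lower from compound 1 to compound 4 (beyond the scatter). Nothing available explains why this change has so large an effect on the read-out.

The compounds shown leave open how an unsubstituted phenyl, a 3-chlorophenyl or a 3-methoxyphenyl would read on this nitrogen, and therefore whether the fluorine of compound 4 or the single ring itself accounts for most of the step away from naphthalen-1-yl. Going by these compounds, these are readings at one concentration, so they show only which compounds have a stronger or weaker effect at that concentration, and how the four compounds would compare at other concentrations remains open.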